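Hydrogen for Hydroxy at the Limit of the Assay

The source may hold more compounds than are shown below. What is called first, only, known or untested is meant among the compounds shown, and "the series" means these compounds.

In a functional assay on P388 cells (Mus musculus) for antiproliferative activity, with a stated time of 72 h (on this read-out higher numbers stand for an effect only at larger amounts of compound and lower numbers for an effect already at smaller amounts), compound 1 (`Cc1cn([C@H]2C[C@H](CF)[C@@H](CO)O2)c(=O)[nH]c1=O`) gives > 100 uM as a limit and not a number. Compound 2 (`Cc1cn([C@@H]2O[C@H](CO)[C@@H](CO)[C@H]2O)c(=O)[nH]c1=O`) gives > 100 uM and this too is a limit. Both compounds sit at the limit of > 100 uM in this assay, at which 2 of the 2 values shown sit, and no finer ranking is possible. Compound 3 (`Cc1cn([C@H]2C[C@H](CO)[C@@H](CO)O2)c(=O)[nH]c1=O`) differs from compound 2 by hydrogen in place of hydroxy on a saturated ring carbon and nothing else. For the measured compounds named here, no measured pair shows this change, so in this assay the expected step of a number no higher from compound 2 to compound 3 (the limit leaves the size open) is none beyond the scatter, in either direction. Compound 3 is estimated at 100 uM with an expected range of 50 uM to 200 uM and will most likely also read as a limit.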

Compound 3, concentration for half-maximal effect: 5 uM
Compound 3: the middle estimate sits 20-fold (1.30 log units) above what was measured, and the stated range ends above it.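

In this assay there is an at least 20-fold lower number from compound 2 to compound 3 (1.30 log units; beyond the scatter) for hydrogen in place of hydroxy on this saturated ring carbon, so what this position carries clearly matters. There is also an at least 20-fold lower number from compound 1 to compound 3 (1.30 log units; beyond the scatter) for hydroxy in place of fluoro on a saturated chain carbon bound to a saturated ring carbon, so that site matters as well. The full size of both steps stays unknown, since each starts from a limit and not a number: the limit of > 100 uM in this assay, at which 2 of the 3 values shown sit.

Going by these compounds, whether an amine or a methoxy group on that ring carbon would read like hydrogen or like hydroxy stays open. So does whether an amine or a chlorine on the chain carbon would read like hydroxy or like fluoro.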